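The compounds below may be only part of what the source reports. "The series", "measured", "known", "first", "only" and "open" are said of these compounds alone.

Compound 1 `COc1ccc(OC(=O)Nc2ccc([Se]C#N)cc2)cc1` and compound 2 `Cc1ccc(OC(=O)Nc2ccc([Se]C#N)cc2)cc1` share one core and differ at a single aromatic carbon. In a functional assay on CCRF-CEM cells (Homo sapiens) for cytotoxicity, read by MTT assay, with a stated time of 72 h (on this read-out lower numbers stand for stronger inhibition of growth and higher numbers for weaker inhibition of growth), compound 1 gives 41500 nM, and compound 2 gives 44700 nM. Compound 2 stands beside compound 1 on these two numbers: the step of a 1.1-fold higher number from compound 1 to compound 2 (0.03 log units; within the scatter) is within the scatter, so the two cannot be told apart. Compound 3 `N#C[Se]c1ccc(NC(=O)Oc2ccc(Cl)cc2)cc1` carries chloro in place of methyl on an aromatic carbon. Among the measured compounds shown here, only that one step bears on this change, and it is within the scatter; no measured step involves chloro. No step beyond the scatter is therefore expected in this assay. The expected step is a 1.0-fold higher number from compound 2 to compound 3 (0.00 log units; within the scatter). Compound 3 is estimated at 45000 nM, with a range from 20000 nM to 100000 nM.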

Compound 3, concentration for total growth inhibition: 45100 nM
Compound 3: the middle estimate sits 1.0-fold (0.00 log units) below what was measured; low and high end bracket the measured number.
By their numbers in this assay, from the lowest: compounds 1, 2 and 3 (each within the scatter of the next).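

In this assay, chloro joins methyl and methoxy on this aromatic carbon, para to a large group: a 1.0-fold higher number from compound 2 to compound 3 (0.00 log units; within the scatter) and a 1.1-fold higher number from compound 1 to compound 3 (0.04 log units; within the scatter) both lie within the scatter. The earlier pair covered only methyl and methoxy, whereas the series now shows that a halogen at this position also cannot be told apart from either. No evidence at hand accounts for this lack of separation. On these data alone, whether an amine, a carboxylic acid or a longer chain on this carbon would move the number beyond the scatter stays open, as do changes elsewhere on the shared core.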